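The source may hold more compounds than are shown below. What is called first, only, known or untested is meant among the compounds shown, and "the series" means these compounds.

Measured compounds:
- compound 1, `Cc1ccc(NC(=O)CSc2nnc(-c3ccoc3C)n2Cc2ccco2)cc1`: 39.8 nM
- compound 2, `Cc1occc1-c1nnc(SCC(=O)Nc2cccc(F)c2)n1Cc1ccco1`: 501 nM
- compound 3, `COc1ccc(NC(=O)CSc2nnc(-c3ccoc3C)n2Cc2ccco2)cc1`: 200 nM

All three were measured in a functional assay on CHO cells for antagonist activity at Orexin receptor type 2 (Homo sapiens), read by FLIPR and calcium flux; on this read-out higher numbers stand for weaker inhibition and lower numbers for stronger inhibition. Among them compound 3 stands second highest: compound 1 lies below it, with a 5.0-fold higher number from compound 1 to compound 3 (0.70 log units; beyond the scatter), and compound 2 lies above it, with a 2.5-fold lower number from compound 2 to compound 3 (0.40 log units; beyond the scatter). The largest gap between the three is a 13-fold higher number from compound 1 to compound 2 (1.10 log units; beyond the scatter).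

Compound 4, `Cc1occc1-c1nnc(SCC(=O)NN2CCc3ccccc32)n1Cc1ccco1`, has not yet been measured. It differs from compound 3 in one place: 2,3-dihydro-1H-indol-1-yl in place of 4-methoxyphenyl on an amide-type nitrogen. The three measured steps all change the group on this same amide-type nitrogen, and they show that swapping one substituted phenyl for another moves the number by a modest to large amount, as in a 5.0-fold higher number from compound 1 to compound 3 (0.70 log units; beyond the scatter) and a 13-fold higher number from compound 1 to compound 2 (1.10 log units; beyond the scatter). None of them, however, replaces the phenyl with a ring attached through nitrogen, so the direction of the step from compound 3 to compound 4 is not settled by the data. Given how sensitive this position has proved, a step beyond the scatter is expected, with the direction uncertain and the range set wide. Compound 4 is therefore estimated at 400 nM, between 80 nM and 2000 nM, which means an expected step of a 2.0-fold higher number from compound 3 to compound 4 (0.30 log units; within the scatter).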

Compound 4, inhibition constant: 1000 nM
Compound 4: middle estimate off by 2.5-fold (0.40 log units), on the low side; low and high end bracket the measured number.
By their numbers in this assay, from the lowest: compound 1; then compound 3; then compounds 2 and 4 (each within the scatter of the next).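

In this assay, 2,3-dihydro-1H-indol-1-yl is the first group shown that joins the amide-type nitrogen through a ring nitrogen rather than a phenyl carbon, and it gives weaker inhibition than 4-methoxyphenyl, with a 5.0-fold higher number from compound 3 to compound 4 (0.70 log units; beyond the scatter), and than 4-methylphenyl, with a 25-fold higher number from compound 1 to compound 4 (1.40 log units; beyond the scatter), the largest step in the set. Compared with 3-fluorophenyl, it cannot be told apart, with a 2.0-fold higher number from compound 2 to compound 4 (0.30 log units; within the scatter), so this position tolerates the new ring no better than the poorer of the two phenyl-type groups it can be set against. Compound 1 remains the strongest inhibitor of the four, and nothing on hand shows what lies behind these steps.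

As far as these compounds go, it remains open whether the weaker inhibition goes with the nitrogen-to-nitrogen link or with the five-membered non-aromatic ring, a question that an unsubstituted phenyl, a benzyl or a piperidin-1-yl group on this nitrogen could help to answer. From the compounds shown here alone, it is also open whether 4-ethylphenyl or 4-chlorophenyl would keep the stronger inhibition seen with 4-methylphenyl.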